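The source may hold more compounds than are shown below. What is called first, only, known or untested is meant among the compounds shown, and "the series" means these compounds.

Compound 1 `O=c1[nH]c(/C=C/c2ccccc2)nc2ccccc12` carries an unsubstituted phenyl ring on its core. In a functional assay on SK-N-MC cells (Homo sapiens) for cytotoxicity, read by MTT assay, with a stated time of 72 h (on this read-out lower numbers stand for stronger inhibition and higher numbers for weaker inhibition), compound 1 gives 1390 nM. Compound 2 `COc1ccc(/C=C/c2nc3ccccc3c(=O)[nH]2)cc1` differs from compound 1 by methoxy in place of hydrogen on an aromatic carbon, set para to a large group. In this assay compound 2 gives > 6250 nM, which is a limit of the assay and not a number. The step of an at least 4.4-fold higher number from compound 1 to compound 2 (0.65 log units; beyond the scatter) therefore points towards weaker inhibition once the methoxy enters.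

Compound 3 `COc1ccc(/C=C/c2nc(Cl)c3ccccc3n2)cc1` carries the same methoxy-bearing ring on a different core; the difference between the two cores is not broken down here. In this assay compound 3 gives 4340 nM, a higher number than compound 1.

Compound 4 `COc1ccc(/C=C/c2nc(Cl)c3ccccc3n2)c(OC)c1` differs from compound 3 by methoxy in place of hydrogen on an aromatic carbon. This is the same kind of change as from compound 1 to compound 2, not the same: here the entering methoxy sits ortho to a large group and meta to a methoxy group, whereas in compound 2 it sits para to a large group. Resting on the step of an at least 4.4-fold higher number from compound 1 to compound 2 (0.65 log units; beyond the scatter), compound 4 is expected to show a weakening of comparable kind, estimated as a 2.1-fold higher number from compound 3 to compound 4 (0.32 log units; beyond the scatter). Compound 4 is therefore expected to give about 9000 nM, between 3500 nM and 25000 nM, with a fair chance that only a limit is reported.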

Compound 4, half-maximal inhibitory concentration: 1750 nM
Compound 4: middle estimate off by 5.1-fold (0.71 log units), on the high side, outside the stated range (below it).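

The entering methoxy gives a 2.5-fold lower number from compound 3 to compound 4 (0.39 log units; beyond the scatter) in this assay, the opposite direction to the earlier step, so this change cannot simply be carried from one core to the other in this series: the same change on two cores in this assay, an at least 4.4-fold higher number (0.65 log units; beyond the scatter) from compound 1 to compound 2 and a 2.5-fold lower number (0.39 log units; beyond the scatter) from compound 3 to compound 4, at least 11-fold (1.04 log units) apart, beyond the scatter of two such steps

Going by these compounds alone, this does not show which difference is responsible, since in compound 4 the methoxy sits ortho to a large group and meta to a methoxy group, a different place from the one it takes in compound 2, and so core and place change together. Compound 2 gives > 6250 nM, a limit of the assay and not a number, so the earlier step has no exact size: the limit of > 6250 nM in this assay, at which 1 of the 4 values shown sits.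

The compounds shown leave open whether a methoxy at the same place on both cores would move the number the same way. They also leave open how another group at that place, such as an amine or a carboxylic acid, would behave on either core.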